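Methoxy step on the carboxyphenyl end, carried to compound 4

The source may hold more compounds than are shown below. What is called first, only, known or untested is meant among the compounds shown, and "the series" means these compounds.

Measured so far:
compound 1 `Cc1c(OCCCCOc2cccc(C(=O)O)c2)ccc(C(=O)CC2CCCC2)c1O`: 92.9%
compound 2 `COc1ccc(C(=O)O)cc1OCCCCOc1ccc(C(=O)CC2CCCC2)c(O)c1C`: 67.6%
compound 3 `Cc1c(OCCCCOc2cccc(C(=O)O)c2)ccc(C(=O)CC(C)C)c1O`: 69.9%

In an assay on HEK293 cells for positive allosteric modulation of metabotropic glutamate receptor 3 (Rattus norvegicus), read by thallium flux, with a stated time of 2.5 min (on this read-out lower numbers stand for smaller maximal responses and higher numbers for larger maximal responses), compound 1 gives 92.9%, compound 2 gives 67.6% and compound 3 gives 69.9%. The change methoxy in place of hydrogen on an aromatic carbon brought the step of a number 25.3 percentage points lower from compound 1 to compound 2 (beyond the scatter). Compound 4 `COc1ccc(C(=O)O)cc1OCCCCOc1ccc(C(=O)CC(C)C)c(O)c1C` is not yet measured; it differs from compound 3 by methoxy in place of hydrogen on an aromatic carbon, the same change in the same surroundings. The cores of compound 1 and compound 3 differ by isopropyl in place of cyclopentyl on a saturated chain carbon bound to a carbonyl carbon, which on its own gave the step of a number 23 percentage points lower from compound 1 to compound 3 (beyond the scatter). Among the measured compounds shown here, for compound 4 a step of a number 22.9 percentage points lower from compound 3 to compound 4 (beyond the scatter) is expected, of about the size seen before, because a number 25.3 percentage points lower from compound 1 to compound 2 (beyond the scatter) is the only guide to this change, and it comes from one pair on a different core. Compound 4 is estimated at 47%, likely between 30% and 65%.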

Compound 4, largest response reached (reported as percent of maximum), in percent of the reference or control that the assay uses: 100%
Estimate against measurement, compound 4: 53 percentage points below, and the stated range ends below it.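

In this assay, methoxy in place of hydrogen on an aromatic carbon gives a number 30.1 percentage points higher from compound 3 to compound 4 (beyond the scatter), the opposite direction to the step on the core of compound 1: the same change on two cores in this assay, a number 25.3 percentage points lower (beyond the scatter) from compound 1 to compound 2 and a number 30.1 percentage points higher (beyond the scatter) from compound 3 to compound 4, 55.4 percentage points apart, beyond the scatter of two such steps. Isopropyl in place of cyclopentyl gives a number 32.4 percentage points higher from compound 2 to compound 4 (beyond the scatter), and this change also reverses direction between cores: the same change on two cores in this assay, a number 23 percentage points lower (beyond the scatter) from compound 1 to compound 3 and a number 32.4 percentage points higher (beyond the scatter) from compound 2 to compound 4, 55.4 percentage points apart, beyond the scatter of two such steps. Among the compounds shown here, neither change can therefore be carried from one core to another as a fixed increment, although these four compounds form only one set of paired changes and do not show how general the reversal is or what underlies it.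

On these data alone, it remains open whether the reversal persists with ethoxy in place of methoxy, or with cyclohexyl in place of isopropyl or cyclopentyl.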